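From Nitrile to Alkyl Chain: A Single Change

The source may hold more compounds than are shown below. What is called first, only, known or untested is meant among the compounds shown, and "the series" means these compounds.

Compound 1, `CCCCCc1cc(C(C)=O)c(O)cc1OCCCCC#N`, gives 14% in an assay on isolated protein for binding affinity to leukotriene B4 receptor 1 (Homo sapiens), tested at 1 uM; a higher number here means more inhibition at the concentration tested (going by the name of the read-out), a lower number less inhibition.
Compound 2, `C=CCc1cc(C(C)=O)c(O)cc1OCCCCCC#N`, gives 41% in this assay.
Compound 3, `CCc1cc(C(C)=O)c(O)cc1OCCCC(C)(C)c1nnn[nH]1`, gives 76% in this assay.

Among these three, compound 2 stands second highest. Compound 1 lies well below it, by a gap beyond the scatter, and compound 3 lies well above it, again by a gap beyond the scatter. Going by the values given here, no two of the measured compounds differ in only one place, so no single step between them can be read off.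

Compound 4, `C=CCc1cc(C(C)=O)c(O)cc1OCCCCCCC`, has not been measured. It differs from compound 2 in one place: ethyl in place of cyano on a saturated chain carbon, five bonds along the chain from an oxygen on an aromatic ring. Because compound 2 gives 41% and the measured compounds offer no comparable exchange of a cyano for an ethyl, the step is expected to be modest and more likely downward than upward, estimated as a number 11 percentage points lower from compound 2 to compound 4 (beyond the scatter). Compound 4 is therefore expected to give about 30% in this assay, estimated to fall between 5% and 60%.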

Compound 4, a percentage reported as inhibition, at one concentration (the size of the read-out at that concentration, not a potency): 8%
Compound 4: the middle estimate sits 22 percentage points above what was measured; low and high end bracket the measured number.
By their numbers in this assay, from the lowest: compounds 4 and 1 (each within the scatter of the next); then compound 2; then compound 3.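

In this assay, going by these compounds alone, this exchange is the first single change that can be read, and it is large: a number 33 percentage points lower from compound 2 to compound 4 (beyond the scatter) when ethyl takes the place of cyano on this saturated chain carbon. Two heavy atoms leave and two enter, so the step reflects which group sits there and not a difference in heavy-atom count. Nothing available here accounts for the size of this step.

What the compounds shown leave open is whether the cyano is specifically needed, or whether a carboxylic acid, an amide or an amine at this place would give a similar number. They also leave open whether the step would keep its size on a longer chain or with a different group elsewhere on the shared core.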